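The source may report more compounds than this note shows. Statements on the series, on what has been measured and on what is new or still open speak of the compounds shown alone.

Compound 2 `COc1ccc([N+](=O)[O-])cc1CSc1nc2cc(NC(=O)NC(C)(C)C)ccc2n1Cc1ccncc1` is one of two compounds tested in an assay on isolated protein for inhibition of Gonadotropin-releasing hormone receptor (Rattus norvegicus) (on this read-out higher numbers stand for weaker inhibition and lower numbers for stronger inhibition), where compound 2 gives 240 nM. Its only companion, compound 1 `CCCn1c(SCc2cc([N+](=O)[O-])ccc2OC)nc2cc(NC(=O)NC(C)(C)C)ccc21`, gives 120 nM in this assay, so compound 2 has the higher of the two numbers, but the step of a 2.0-fold higher number from compound 1 to compound 2 (0.30 log units; within the scatter) lies within the scatter and no order can be claimed.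

Compound 3 `COc1ccc([N+](=O)[O-])cc1CSc1nc2cc(NC(=O)NC(C)(C)C)ccc2n1-c1ccccc1` is not yet measured. It differs from compound 2 by phenyl in place of (pyridin-4-yl)methyl on an aromatic nitrogen. Among the measured compounds shown here, the one measured step, from compound 1 to compound 2, concerned the group carried by the saturated carbon on that nitrogen, not the removal of that carbon, and it stayed within the scatter. For the measured compounds named here, no measured step therefore bears directly on this change, and no step beyond the scatter is expected. Compound 3 is estimated at 300 nM in this assay, within 100 nM to 1000 nM, meaning an expected step of a 1.3-fold higher number from compound 2 to compound 3 (0.10 log units; within the scatter).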

Compound 3, half-maximal inhibitory concentration: > 2600 nM
Compound 3: only a limit was reported; the forecaster's own chance of this, stated with the estimate: 5%; middle value at least 8.6-fold (0.93 log units) from the limit.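

The value of compound 3 in this assay is a limit of the assay and not a number: the limit of > 2600 nM in this assay, at which 1 of the 3 values shown sits. Even so, the change reads clearly, with an at least 10-fold higher number from compound 2 to compound 3 (1.03 log units; beyond the scatter) and an at least 21-fold higher number from compound 1 to compound 3 (1.33 log units; beyond the scatter), whereas propyl and (pyridin-4-yl)methyl on the aromatic nitrogen had stayed within the scatter of each other. This position therefore accepts both of those groups but not phenyl, and among the compounds shown, phenyl alone lacks a saturated carbon bound to that nitrogen.

The compounds shown leave open whether the loss follows from removing that saturated carbon or from the carbon-only ring itself, a question that benzyl on the same nitrogen would address. They also leave open how methyl or a chain ending in an amine would read here.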